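Swapping a terminal methyl for hydroxy on the sulfonamide chain

A few compounds are considered here, and "the series" means these few. Any claim that something is new, unique, unknown or untested is made for them only; others in the source may bear on it.

Of the compounds shown here, three sharing one core have been measured in a functional assay on A549 cells (Homo sapiens) for antiproliferative activity, read by CCK-8 assay, with a stated time of 72 h; on this read-out higher numbers stand for weaker inhibition of growth and lower numbers for stronger inhibition of growth. Compound 1 `CCCNS(=O)(=O)c1ccc(Nc2ncc3c(n2)N(C2CCCC2)[C@H](CC)C(=O)N3C)cc1` gives 563 nM, compound 2 `CC[C@@H]1C(=O)N(C)c2cnc(Nc3ccc(S(=O)(=O)NC4CCCC4)cc3)nc2N1C1CCCC1` gives 1150 nM, and compound 3 `CCCCNS(=O)(=O)c1ccc(Nc2ncc3c(n2)N(C2CCCC2)[C@H](CC)C(=O)N3C)cc1` gives 477 nM. Compound 3 has the lowest number of the three, though its gap to compound 1 lies within the scatter; only compound 2 sits clearly apart, with a 2.4-fold lower number from compound 2 to compound 3 (0.38 log units; beyond the scatter). Compound 4 `CC[C@@H]1C(=O)N(C)c2cnc(Nc3ccc(S(=O)(=O)NCCCO)cc3)nc2N1C1CCCC1` differs from compound 3 by hydroxy in place of methyl on a saturated chain carbon, three bonds along the chain from a sulfonamide nitrogen. For the measured compounds named here, no measured step exchanges a methyl for a hydroxy; the nearest comparison, a 1.2-fold lower number from compound 1 to compound 3 (0.07 log units; within the scatter), shows that altering the end of this chain barely moved the number. In this assay compound 4 is therefore expected to show a 1.3-fold higher number from compound 3 to compound 4 (0.10 log units; within the scatter), an estimate of 600 nM with a range from 250 nM to 1400 nM.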

Compound 4, concentration for 50% growth inhibition: 437 nM
Estimate against measurement, compound 4: 1.4-fold (0.14 log units) above; measured number inside the range.
By their numbers in this assay, from the lowest: compounds 4, 3 and 1 (each within the scatter of the next); then compound 2.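

In this assay, for the compounds shown here, the earlier compounds carried only carbon groups on the sulfonamide nitrogen, and this chain also tolerates a hydroxy at its end, with a 1.1-fold lower number from compound 3 to compound 4 (0.04 log units; within the scatter) and a 1.3-fold lower number from compound 1 to compound 4 (0.11 log units; within the scatter). The 3-hydroxypropyl chain also keeps the advantage over cyclopentyl already seen with the plain chains, with a 2.6-fold lower number from compound 2 to compound 4 (0.42 log units; beyond the scatter). No evidence here explains why this exchange leaves the number within the scatter. Still open, on these data alone, is whether an amine or a carboxylic acid at the chain end, or a longer chain ending in hydroxy, would be tolerated equally well.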